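The source may report more compounds than this note shows. Statements on the series, on what has been measured and on what is new or still open speak of the compounds shown alone.

Compound 1, `C=C1CCC[C@H]2[C@](C)(CC[C@]3(C)CC[C@H]([C@@H](C)C(=O)O)OO3)[C@@H](C)CC[C@]12C`: in a functional assay on OVCAR-3 cells (Homo sapiens) for inhibition (a lower number here means a stronger inhibitor of growth, a higher number a weaker inhibitor of growth), compound 1 gives 1850 nM.
Compound 2, `C=C1CCCC(C)(C)C1CC[C@]1(C)CC[C@H]([C@@H](C)C(=O)OC)OO1`: in this assay compound 2 gives 21800 nM.
Compound 3, `CC1=C(CC/C(C)=C/CC[C@@]2(C)CC[C@@H]([C@H](C)C(=O)O)OO2)C(C)(C)CCC1`: in this assay compound 3 gives no number, only a limit, > 100000 nM.

Compound 3 therefore stands at the weak edge of what this assay can report; (the limit of > 100000 nM in this assay, at which 1 of the 3 values shown sits). Whether its true value lies just past that edge or far beyond it cannot be told from the measurement.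

Compound 4, `CC1=C(CC/C(C)=C/CC[C@@]2(C)CC[C@H]([C@H](C)C(=O)O)OO2)C(C)(C)CCC1`, has not been measured. It differs from compound 3 as follows: the two compounds have the same atoms and bonds and differ only in configuration as drawn: 1 of 4 stereo elements differ; a stereocentre at a saturated ring carbon is drawn S in compound 3 and R in compound 4. Both keep the same atoms and bonds; only the configuration at one saturated ring carbon changes. Such a swap can leave growth inhibition unchanged or shift it either way, and with compound 3 at the limit nothing here shows which way. The expected step from compound 3 to compound 4 in this assay is an at least 1.6-fold lower number from compound 3 to compound 4 (0.22 log units; that floor lies within the scatter). Compound 4 is thus estimated at 60000 nM, with a likely range from 10000 nM to 300000 nM.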

Compound 4, concentration for 50% growth inhibition: > 5000 nM
Compound 4 ended at the assay's limit; the forecaster's own chance of this, stated with the estimate: 45%; the middle value is on the limit's open side.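

Within the data shown here, compound 3 and compound 4 each give only a limit in this assay, not a number, and no step between them can be read. The compounds shown leave open whether changing the configuration at this one saturated ring carbon alters growth inhibition at all, and in which direction.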